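Swapping the aryl group on the anilino nitrogen of compound 1

The source may report more compounds than this note shows. Statements on the series, on what has been measured and on what is new or still open speak of the compounds shown alone.

Measured so far:
compound 1, `O=C1C=C(Nc2ccc(I)cc2)C(=O)c2c1nc1n2[C@H]2OC[C@@H](O)[C@H]2OC1`: 2300 nM
compound 2, `CCCc1ccc(NC2=CC(=O)c3c(nc4n3[C@H]3OC[C@@H](O)[C@H]3OC4)C2=O)cc1`: > 4000 nM
compound 3, `O=C1C(N2CCCCC2)=CC(=O)c2c1nc1n2[C@H]2OC[C@@H](O)[C@H]2OC1`: > 8000 nM

For the measured compounds named here, in a functional assay on ECa-109 cells for inhibition, with ECa-109 cell line (Homo sapiens) as the target, read by sulforhodamine B assay (on this read-out higher numbers stand for weaker inhibition and lower numbers for stronger inhibition), compound 1 gives 2300 nM, the only number among the three values shown. For compound 2 this assay reports only a limit, > 4000 nM, as noted under (the limit of > 4000 nM in this assay, at which 1 of the 3 values shown sits). For compound 3 it likewise reports only a limit, > 8000 nM, as noted under (the limit of > 8000 nM in this assay, at which 1 of the 3 values shown sits). The untested compound 4, `COc1cccc(NC2=CC(=O)c3nc4n(c3C2=O)[C@H]2OC[C@@H](O)[C@H]2OC4)c1`, differs from compound 1 by 3-methoxyphenyl in place of 4-iodophenyl on an amine nitrogen. Going by the values given here, no step between two measured compounds is available to gauge such a swap, so the step in this assay from compound 1 to compound 4 is expected to be modest, likely toward weaker inhibition, a 1.7-fold higher number from compound 1 to compound 4 (0.24 log units; within the scatter). Compound 4 is accordingly estimated at 4000 nM, between 1500 nM and 12000 nM.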

Compound 4, half-maximal inhibitory concentration: 7620 nM
Compound 4: middle estimate off by 1.9-fold (0.28 log units), on the low side, within the range that was stated.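

In this assay, for the compounds shown here, the swap on the amine nitrogen gives a 3.3-fold higher number from compound 1 to compound 4 (0.52 log units; beyond the scatter), the first step at this place that can be read as a number. It shows that the aryl group here matters, with 3-methoxyphenyl giving weaker inhibition than 4-iodophenyl. Nothing measured here speaks to the cause of this step.

From the compounds shown here alone, whether the loss follows the methoxy group or its place on the ring stays open; 4-methoxyphenyl or 3-iodophenyl on the same nitrogen would separate the two. Going by these compounds, how a carboxylic acid on that ring would read is also open.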